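Swapping naphthalenyl for chlorophenoxy: an expected acidity value

The compounds below may be only part of what the source reports. "The series", "measured", "known", "first", "only" and "open" are said of these compounds alone.

Compound 1 `COc1ccc(F)cc1CNCCCNc1ccnc2cc(Oc3ccc(Cl)cc3)ccc12` gives 9.28 in a physicochemical assay for acid dissociation.
Compound 2 `COc1ccc(F)cc1CNCCCNc1ccnc2cc(-c3cccc4ccccc34)ccc12` gives 9.47 in this assay.
Compound 3 `COc1cccc(CNCCCNc2ccnc3cc(-c4cccc5ccccc45)ccc23)c1O` gives 9.47 in this assay.

Compound 4 `COc1cccc(CNCCCNc2ccnc3cc(Oc4ccc(Cl)cc4)ccc23)c1O` has not been measured. It differs from compound 3 by one change, (4-chlorophenoxy in place of naphthalen-1-yl on an aromatic carbon). The same change has already been made once, from compound 2 to compound 1, (4-chlorophenoxy in place of naphthalen-1-yl on an aromatic carbon), and there it gave a number 0.19 log units lower from compound 2 to compound 1 (within the scatter). The two cores on which the change is made differ by 2-hydroxy-3-methoxyphenyl in place of 5-fluoro-2-methoxyphenyl on a saturated chain carbon bound to an amine nitrogen, and that difference itself brought no change at the digits printed from compound 2 to compound 3 (within the scatter). The place of the change reads the same in both pairs, so it is the same change. For compound 4 the step in this assay is therefore expected to be a number 0.17 log units lower from compound 3 to compound 4 (within the scatter), resting on the earlier step of a number 0.19 log units lower from compound 2 to compound 1 (within the scatter) from compound 2 to compound 1. Compound 4 is estimated to give 9.3, likely between 9 and 9.6.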

Compound 4, acid dissociation constant: 9.28
Compound 4: the middle estimate sits 0.02 log units above what was measured, and the stated range covers the measured number.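

In this assay, 4-chlorophenoxy in place of naphthalen-1-yl gives a number 0.19 log units lower from compound 3 to compound 4 (within the scatter), matching in size the step on the other core, while 2-hydroxy-3-methoxyphenyl in place of 5-fluoro-2-methoxyphenyl gives no change at the digits printed from compound 1 to compound 4 (within the scatter) on the 4-chlorophenoxy compounds. The change therefore carried over between these two cores with the same outcome, but both of its steps lie within the scatter, so this does not show that the change has a real effect of its own, or that it would carry over to other cores. No measurement shown here explains these numbers.

Still open, as far as these compounds go, is whether the same outcome would hold with a carboxylic acid in place of 4-chlorophenoxy. From the compounds shown here alone, a longer chain in place of the saturated chain of the shared core is equally open.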